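Exchanging One Five-Membered Ring on a Shared Core

The source may hold more compounds than are shown below. What is called first, only, known or untested is meant among the compounds shown, and "the series" means these compounds.

Compound 2 `COc1cc(OC)c2c(=O)cc(C(=O)Nc3cccc(-c4nccs4)c3)[nH]c2c1` and compound 1 `COc1cc(OC)c2c(=O)cc(C(=O)Nc3cccc(N4CCCC4)c3)[nH]c2c1` share a core and differ in a single group. In a functional assay on SUP-B15 cells (Homo sapiens) for antiproliferative activity, with a stated time of 72 h (on this read-out lower numbers stand for an effect already at smaller amounts and higher numbers for an effect only at larger amounts of compound), compound 2 gives > 54000 nM, which is a limit of the assay and not a number. Compound 1 likewise gives > 58600 nM in this assay, again only a limit. Consequently a step that the two limits leave unreadable from compound 1 to compound 2 cannot be read. Compound 3 `COc1cc(OC)c2c(=O)cc(C(=O)Nc3cccc(-n4ccnc4)c3)[nH]c2c1` carries 1H-imidazol-1-yl in place of 1,3-thiazol-2-yl on an aromatic carbon. With both measured values sitting at limits (the limit of > 54000 nM in this assay, at which 1 of the 2 values shown sits, and (the limit of > 58600 nM in this assay, at which 1 of the 2 values shown sits)), no readable step bears on this change, so the expected step is a step that the limit leaves unreadable from compound 2 to compound 3. Compound 3 is therefore estimated near 60000 nM, plausibly between 15000 nM and 200000 nM, most likely reported again as a limit.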

Compound 3, half-maximal effective concentration: > 16300 nM
Compound 3 ended at the assay's limit (the forecaster's own chance of this, stated with the estimate: 85%); the middle value does not contradict the limit.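

For the compounds shown here, compound 1, compound 2 and compound 3 all end at limits in this assay, not at numbers, and no step among them can be read. From the compounds shown here alone, how far apart these three compounds truly lie remains open.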